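Ethyl to Methoxy on the Aryl Ring: What to Expect

The source may report more compounds than this note shows. Statements on the series, on what has been measured and on what is new or still open speak of the compounds shown alone.

Measured compounds:
Compound 1, `COc1cccc(OC)c1OCCNC[C@H]1Oc2ccccc2O[C@@H]1C`: 11.5 nM
Compound 2, `CCc1ccc([C@H]2Oc3ccccc3O[C@@H]2CNCCOc2c(OC)cccc2OC)cc1`: 15.1 nM

In a functional assay for antagonist activity at Adrenergic receptor alpha-1 (Rattus norvegicus) (a lower number here means tighter binding, a higher number weaker binding), compound 2 stands with the higher of the two numbers, yet the step of a 1.3-fold higher number from compound 1 to compound 2 (0.12 log units; within the scatter) is within the usual scatter, so the two compounds cannot be told apart on these data. The unmeasured compound 3, `COc1ccc([C@H]2Oc3ccccc3O[C@@H]2CNCCOc2c(OC)cccc2OC)cc1`, differs from compound 2 by methoxy in place of ethyl on an aromatic carbon. Within the data shown here, no measured step touches this position: the one step known, from compound 1 to compound 2, replaced a methyl on the saturated ring by 4-ethylphenyl and barely moved the number. That step suggests the group at this end is tolerated broadly, but it says nothing directly about ethyl versus methoxy. The expectation is therefore no step beyond the scatter, a 1.0-fold lower number from compound 2 to compound 3 (0.00 log units; within the scatter). Compound 3 is expected to give 15 nM in this assay, estimated to fall between 6 nM and 40 nM.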

Compound 3, dissociation constant: 2.14 nM
Compound 3: the middle estimate sits 7.0-fold (0.85 log units) above what was measured; measured number outside the range, below it.
By their numbers in this assay, from the lowest: compound 3; then compounds 1 and 2 (each within the scatter of the next).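

In this assay the step of a 7.1-fold lower number from compound 2 to compound 3 (0.85 log units; beyond the scatter) shows that this place on the aromatic ring is not indifferent, even though ethyl and methoxy have the same count of heavy atoms and differ only in one carbon exchanged for an oxygen. It also changes how the earlier pair reads: compound 1 and compound 2 could not be told apart, whereas the step of a 5.4-fold lower number from compound 1 to compound 3 (0.73 log units; beyond the scatter) lies beyond the scatter, so replacing that methyl with a substituted phenyl can matter, depending on what the phenyl carries. Nothing available here explains why the two groups differ.

With only ethyl and methoxy shown at this place, it stays open whether the oxygen itself is what counts. A hydroxyl, an amine or a longer ethoxy chain there would help to settle that.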